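Aldehyde dehydrogenase 1A1 series: bromo to fluoro step

The compounds below may be only part of what the source reports. "The series", "measured", "known", "first", "only" and "open" are said of these compounds alone.

compound 1 `Cc1cccc(Cn2c(CN3CCN(C(=O)c4ccc(C#N)cc4)CC3)nc3ccccc32)c1`: 20.8%
compound 2 `Cc1cccc(Cn2c(CN3CCN(C(=O)c4ccc(Br)cc4)CC3)nc3ccccc32)c1`: 25.8%

Among the measured compounds shown here, in an assay on isolated protein for inhibition of aldehyde dehydrogenase 1A1 (Homo sapiens), read by spectrophotometry, tested at 10 uM (on this read-out higher numbers stand for more inhibition at the one concentration tested (going by the name of the read-out) and lower numbers for less inhibition), compound 2 holds the higher of the two numbers, with compound 1 nearest; the single measured step, a number 5 percentage points higher from compound 1 to compound 2 (within the scatter), lies within the scatter, so the two cannot be ordered. Compound 3 `Cc1cccc(Cn2c(CN3CCN(C(=O)c4ccc(F)cc4)CC3)nc3ccccc32)c1` differs from compound 2 by fluoro in place of bromo on an aromatic carbon. For the measured compounds named here, the only step that bears on this change is a number 5 percentage points higher from compound 1 to compound 2 (within the scatter), a change at the same aromatic carbon that stayed within the scatter, so no step beyond the scatter is expected in this assay. The step expected is a number 5.8 percentage points lower from compound 2 to compound 3 (within the scatter). For compound 3 the estimate is 20%, expected between 6% and 36%.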

Compound 3, a percentage reported as inhibition, at one concentration (the size of the read-out at that concentration, not a potency): 27.1%
Beside the measured number, compound 3's estimate is 7.1 percentage points below it; measured number inside the range.
By their numbers in this assay, from the lowest: compounds 1, 2 and 3 (each within the scatter of the next).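

With fluoro on this aromatic carbon, para to a large group, this assay gives a number 1.3 percentage points higher from compound 2 to compound 3 (within the scatter) and a number 6.3 percentage points higher from compound 1 to compound 3 (within the scatter). Cyano, bromo and fluoro at this position therefore all lie within the scatter of one another, so the three compounds cannot be ordered and this change gives no step beyond the scatter. No measurement at hand bears on why these numbers stay so close.

Still open, as far as these compounds go, is whether an amine or a carboxylic acid on this carbon would give a step beyond the scatter.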